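The source may report more compounds than this note shows. Statements on the series, on what has been measured and on what is new or still open speak of the compounds shown alone.

Three compounds share one core and differ only in the group attached to the amine nitrogen. In a functional assay on the whole organism (strain albino) for inhibition, with Rattus norvegicus as the target, read by paw edema, with stated times of 1 h and 2 h, at a dose of 20 mmol/kg by the intraperitoneal route (a higher number here means more inhibition at the dose given (going by the name of the read-out), a lower number less inhibition), compound 3 `CCOC(=O)C(=O)NC1=C(C#N)C2C(N3CCCC3)CCCCN2C(=O)N1c1ccccc1` gives 83.6%, the highest of the three numbers. Compound 1 `N#CC1=C(/N=C/Nc2ccc([N+](=O)[O-])cc2)N(c2ccccc2)C(=O)N2CCCCC(N3CCCC3)C12` gives 41.5% in this assay, and compound 2 `N#CC1=C(NCN2CCCCC2)N(c2ccccc2)C(=O)N2CCCCC(N3CCCC3)C12` gives 36.9%. The step of a number 4.6 percentage points lower from compound 1 to compound 2 (within the scatter) stays within the scatter, whereas a number 42.1 percentage points higher from compound 1 to compound 3 (beyond the scatter) and a number 46.7 percentage points higher from compound 2 to compound 3 (beyond the scatter) are both large gains that arrive with the (ethoxycarbonyl)carbonyl group. Compound 4 `N#CC1=C(NC(=O)c2ccccc2O)N(c2ccccc2)C(=O)N2CCCCC(N3CCCC3)C12` has not yet been measured; it keeps the carbonyl on the amine nitrogen but carries 2-hydroxyphenyl in place of ethoxycarbonyl on a carbonyl carbon. Among the measured compounds shown here, the two large steps bear on this change only in part, since no measured compound carries a (2-hydroxyphenyl)carbonyl group. Compound 3 owes its standing to the (ethoxycarbonyl)carbonyl group, as shown by a number 46.7 percentage points higher from compound 2 to compound 3 (beyond the scatter), and the loss of the ethoxycarbonyl part is therefore expected to cost something. The expected step is a number 21.6 percentage points lower from compound 3 to compound 4 (beyond the scatter), a partial retreat rather than a full return. Compound 4 is estimated at 62%, with a range from 38% to 86%.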

Compound 4, a percentage reported as inhibition, in the whole organism at one dose (the size of the read-out at that dose, not a potency): 53.8%
Compound 4: the middle estimate sits 8.2 percentage points above what was measured, and the stated range covers the measured number.
By their numbers in this assay, from the lowest: compounds 2 and 1 (each within the scatter of the next); then compound 4; then compound 3.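

Keeping the carbonyl on the amine nitrogen while exchanging ethoxycarbonyl for 2-hydroxyphenyl gives a number 29.8 percentage points lower from compound 3 to compound 4 (beyond the scatter), so a carbonyl at this place does not by itself secure the high number of compound 3. Part of the gain remains, however, with a number 16.9 percentage points higher from compound 2 to compound 4 (beyond the scatter) and a number 12.3 percentage points higher from compound 1 to compound 4 (beyond the scatter), so the (2-hydroxyphenyl)carbonyl group also stands above both groups without a carbonyl at this nitrogen. No measurement shown explains why these groups differ.

The compounds shown leave open how much of the result depends on the hydroxyl on the phenyl ring, since a plain phenyl on the same carbonyl is not among them. They also leave open whether a carboxylic acid or a methoxycarbonyl group could stand in for ethoxycarbonyl on that carbonyl carbon.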